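A few compounds are considered here, and "the series" means these few. Any claim that something is new, unique, unknown or untested is made for them only; others in the source may bear on it.

Series notes. Compound 1 `O=C(COc1ccc(C(=O)/C=C/c2ccc(Cl)cc2Cl)cc1)N[C@H]1CCOC1=O` gives 26500 nM in a functional assay on MGC-803 cells (Homo sapiens) for antiproliferative activity, read by MTT assay, with a stated time of 72 h; on this read-out lower numbers stand for stronger inhibition and higher numbers for weaker inhibition; compound 2 `CC(C)(C)c1ccc(/C=C/C(=O)c2ccc(OCC(=O)N[C@H]3CCOC3=O)cc2)cc1` gives 17200 nM in the same read-out. Among the measured compounds shown here, the only measured step, a 1.5-fold lower number from compound 1 to compound 2 (0.19 log units; within the scatter), exchanges the whole aryl group on the chain. On the two numbers in hand compound 2 carries the lower value, but its number and that of compound 1 lie within the scatter of each other, so no ranking follows.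

Compound 3 `CC(C)c1ccc(/C=C/C(=O)c2ccc(OCC(=O)N[C@H]3CCOC3=O)cc2)cc1` differs from compound 2 by hydrogen in place of methyl on a saturated chain carbon bound to an aromatic carbon and two saturated chain carbons. For the measured compounds named here, no measured step touches this position; the single step available, from compound 1 to compound 2 , concerns a different and larger exchange and stayed within the scatter, so it offers no direction for a one-carbon trim of the tert-butyl group. The expected change in this assay is therefore none beyond the scatter.

For compound 3 the estimated value is 18000 nM, with a range from 8000 nM to 40000 nM. The expected step is a 1.0-fold higher number from compound 2 to compound 3 (0.02 log units; within the scatter).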

Compound 3, half-maximal inhibitory concentration: 16800 nM
Compound 3: the middle estimate sits 1.1-fold (0.03 log units) above what was measured; low and high end bracket the measured number.
By their numbers in this assay, from the lowest: compounds 3, 2 and 1 (each within the scatter of the next).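

In this assay the trim of tert-butyl to isopropyl gives a 1.0-fold lower number from compound 2 to compound 3 (0.01 log units; within the scatter), so losing this one methyl from the saturated chain carbon leaves the number within the scatter. The exchange of 2,4-dichlorophenyl for 4-isopropylphenyl gives a 1.6-fold lower number from compound 1 to compound 3 (0.20 log units; within the scatter) and also stays within the scatter, so the three aryl groups shown on the chain cannot be told apart in this read-out. No accompanying data bear on these results.

On these data alone, it remains open whether an amine, a carboxylic acid or a longer chain in place of the isopropyl group would move the number beyond the scatter. As far as these compounds go, it is equally open whether changes to the shared core, away from this aryl group, would do so.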